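Thiophene-to-methylthiophenyl swap in a vinyl sulfone series

The compounds below may be only part of what the source reports. "The series", "measured", "known", "first", "only" and "open" are said of these compounds alone.

Compound 1 `Cc1ccc(S(=O)(=O)/C(=C/c2sccc2C)C(=O)c2ccc(Br)cc2)cc1` and compound 2 `CSc1ccc(/C=C(\C(=O)c2ccc(Br)cc2)S(=O)(=O)c2ccc(C)cc2)cc1` share a core and differ in one place. In a functional assay on DU-145 cells (Homo sapiens) for inhibition, read by trypan blue exclusion, with a stated time of 96 h (on this read-out higher numbers stand for weaker inhibition of growth and lower numbers for stronger inhibition of growth), compound 1 gives 25000 nM and compound 2 gives 1000 nM; the step of a 25-fold lower number from compound 1 to compound 2 (1.40 log units; beyond the scatter) goes with the change (4-(methylsulfanyl)phenyl in place of 3-methylthiophen-2-yl on a double-bonded chain carbon bound to a double-bonded chain carbon). Compound 3 `Cc1ccsc1/C=C(\C(=O)c1ccc(Cl)cc1)S(=O)(=O)Cc1ccc(Cl)cc1` has a different core; how it differs from compound 1 is not broken down here. In this assay compound 3 gives 25000 nM, level with compound 1 within the scatter. Compound 4 `CSc1ccc(/C=C(\C(=O)c2ccc(Cl)cc2)S(=O)(=O)Cc2ccc(Cl)cc2)cc1` carries the change 4-(methylsulfanyl)phenyl in place of 3-methylthiophen-2-yl on a double-bonded chain carbon bound to a double-bonded chain carbon on the core of compound 3, the same change as before. For the measured compounds named here, the step from compound 3 to compound 4 is expected to be a 17-fold lower number from compound 3 to compound 4 (1.22 log units; beyond the scatter), beside the earlier 25-fold lower number from compound 1 to compound 2 (1.40 log units; beyond the scatter), because a 25-fold lower number from compound 1 to compound 2 (1.40 log units; beyond the scatter) is the only measured instance of this change. Compound 4 is therefore estimated at 1500 nM, between 400 nM and 6000 nM.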

Compound 4, concentration for 50% growth inhibition: 10000 nM
Estimate against measurement, compound 4: 6.7-fold (0.82 log units) below; measured number outside the range, above it.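

In this assay 4-(methylsulfanyl)phenyl in place of 3-methylthiophen-2-yl goes with a 2.5-fold lower number from compound 3 to compound 4 (0.40 log units; beyond the scatter) on the second core, the same direction as on the first. The data do not show which of the differences between the two cores goes with the change in step size, and two pairs set no rule for any further core. The direction carries over between these two cores, but the size does not: the same change on two cores in this assay, a 25-fold lower number (1.40 log units; beyond the scatter) from compound 1 to compound 2 and a 2.5-fold lower number (0.40 log units; beyond the scatter) from compound 3 to compound 4, 10-fold (1.00 log units) apart, beyond the scatter of two such steps

Still open, going by these compounds, is whether the methylsulfanyl group or the six-membered ring goes with the lower numbers, which a plain phenyl or a 4-methoxyphenyl at this place would separate. Also open, on these data alone, is how a 4-aminophenyl there would read on either core.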